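Restoring the Cyclopentylmethoxycarbonyl Group in Compound 3

The source may hold more compounds than are shown below. What is called first, only, known or untested is meant among the compounds shown, and "the series" means these compounds.

Compound 1 `NCc1ccc(C(=O)Nc2ccncc2)cc1-c1cccc(C(=O)OCC2CCCC2)c1`: 5 nM
Compound 2 `NCc1ccc(C(=O)Nc2ccncc2F)cc1-c1cccc(C(=O)O)c1`: 55 nM

In an assay on isolated protein for inhibition of Rho-associated protein kinase 2 (Homo sapiens), read by radiometric assay (a higher number here means a weaker inhibitor, a lower number a stronger inhibitor), compound 1 gives 5 nM, while compound 2 gives 55 nM. Compound 2 therefore holds the higher of the two numbers, and its distance from compound 1 lies beyond the usual scatter. For the measured compounds named here, the two compounds differ in two places at once, so their values show only that the combined change weakens inhibition; no single step between them is measured.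

Compound 3 `NCc1ccc(C(=O)Nc2ccncc2F)cc1-c1cccc(C(=O)OCC2CCCC2)c1` is derived from compound 2 by cyclopentylmethyl in place of hydrogen on an oxygen next to a carbonyl group. Compound 3 thus carries the cyclopentylmethoxycarbonyl group found in compound 1. Because compound 1 gives 5 nM in this assay, compound 3 is expected to move toward that value. The step from a 5.5-fold lower number from compound 2 to compound 3 (0.74 log units; beyond the scatter) is expected to be a drop to a lower number, beyond the scatter. For compound 3 the estimate in this assay is 10 nM, within a range from 3 nM to 40 nM.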

Compound 3, half-maximal inhibitory concentration: 13 nM
Beside the measured number, compound 3's estimate is 1.3-fold (0.11 log units) below it, and the stated range covers the measured number.
By their numbers in this assay, from the lowest: compound 1; then compound 3; then compound 2.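

In this assay, cyclopentylmethyl in place of hydrogen on an oxygen next to a carbonyl group, with the fluoro kept, gives a 4.2-fold lower number from compound 2 to compound 3 (0.63 log units; beyond the scatter), so this change taken alone strengthens inhibition. The fluoro can now also be read alone: fluoro in place of hydrogen on an aromatic carbon gives a 2.6-fold higher number from compound 1 to compound 3 (0.41 log units; beyond the scatter), so it weakens inhibition, and both parts of the combined change separating the first two compounds point the same way. No measurement offered here accounts for either step.

The compounds shown leave open whether a methyl or a benzyl group on an oxygen next to a carbonyl group would match cyclopentylmethyl. They also leave open whether the fluoro step would keep its direction and size alongside the carboxy group, or whether chloro on that aromatic carbon would behave like fluoro.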